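The source may report more compounds than this note shows. Statements on the series, on what has been measured and on what is new or still open speak of the compounds shown alone.

Measured compounds:
Compound 1, `CCSc1nnc(-c2cc(OC)c(OC)c(OC)c2)n1-c1ccc(OC)cc1`, gives 57700 nM in a functional assay on PC-3 cells (Homo sapiens) for inhibition, read by MTT assay, with a stated time of 48 h; on this read-out higher numbers stand for weaker inhibition and lower numbers for stronger inhibition.
Compound 2, `COc1ccc(-n2c(SCC(=O)c3ccc4ccccc4c3)nnc2-c2cc(OC)c(OC)c(OC)c2)cc1`, reaches only > 60000 nM, which is a limit of the assay and not a number.

Among the compounds with values here, compound 1 thus stands on the only number recorded in this assay; the other entry is a limit. Compound 3, `CCOC(=O)CSc1nnc(-c2cc(OC)c(OC)c(OC)c2)n1-c1ccc(OC)cc1`, differs from compound 1 by ethoxycarbonyl in place of methyl on a saturated chain carbon bound to a sulfur. Within the data shown here, the single measured step, an at least 1.0-fold higher number from compound 1 to compound 2 (0.01 log units; that floor lies within the scatter), alters the same place with a different group. It ends at the limit of > 60000 nM in this assay, at which 1 of the 2 values shown sits, so it sets no direction for the present change. Among the measured compounds shown here, no measured step for ethoxycarbonyl at this position exists. The account therefore expects a step of a 1.0-fold higher number from compound 1 to compound 3 (0.02 log units; within the scatter), within the scatter, with a fair chance that only a limit is returned. Compound 3 is estimated at 60000 nM, with a range from 25000 nM to 150000 nM.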

Compound 3, half-maximal inhibitory concentration: > 60000 nM
Compound 3: only a limit was reported; the forecaster's own chance of this, stated with the estimate: 50%; the middle value lies on the limit itself.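

In this assay, ethoxycarbonyl in place of methyl on a saturated chain carbon bound to a sulfur gives an at least 1.0-fold higher number from compound 1 to compound 3 (0.01 log units; that floor lies within the scatter). For compound 3, the entry > 60000 nM is a limit of the assay and not a number, and the step from compound 2 to compound 3 cannot be read, since both entries are limits. A second, different group at this place has now ended on the same limit, so compound 1 remains the only compound with a number, and the size of neither change can be told: the limit of > 60000 nM in this assay, at which 2 of the 3 values shown sit.

As far as these compounds go, it remains open whether any group at this place would give a readable number, and whether that number would differ from that of compound 1, which gives 57700 nM. A carboxylic acid, an amine or a longer plain alkyl chain on this carbon could each answer that.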